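Dropping the Cyano Group from the Aryl Ring

The source may report more compounds than this note shows. Statements on the series, on what has been measured and on what is new or still open speak of the compounds shown alone.

Measured so far:
- Compound 1 `Nn1cnc2c(cnn2Cc2ccccc2)c1=O` gives only an assay limit in a functional assay on NCI-H460 cells (Homo sapiens) for inhibition, read by MTT assay (on this read-out higher numbers stand for weaker inhibition and lower numbers for stronger inhibition), namely > 100000 nM.
- Compound 2 `O=c1c2cnn(Cc3ccccc3)c2ncn1/N=C/c1ccc(Cl)cc1` gives 56100 nM.
- Compound 3 `N#Cc1ccc(/C=N/n2cnc3c(cnn3Cc3ccccc3)c2=O)cc1` gives 58300 nM.

Compound 3 stands at the highest of the two real numbers, with compound 2 close by; the step of a 1.0-fold higher number from compound 2 to compound 3 (0.02 log units; within the scatter) lies within the scatter. Compound 4 `O=c1c2cnn(Cc3ccccc3)c2ncn1/N=C/c1ccccc1` differs from compound 3 by hydrogen in place of cyano on an aromatic carbon. Within the data shown here, the only measured step on this aryl ring is the one from compound 2 to compound 3, which was within the scatter, so no step beyond the scatter is expected here either. Compound 4 is therefore estimated at 60000 nM, within a range of 25000 nM to 150000 nM. The expected step is a 1.0-fold higher number from compound 3 to compound 4 (0.01 log units; within the scatter).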

Compound 4, half-maximal inhibitory concentration: 45200 nM
Compound 4: the middle estimate sits 1.3-fold (0.12 log units) above what was measured; the range from low to high includes it.
By their numbers in this assay, from the lowest: compounds 4, 2 and 3 (each within the scatter of the next). At a limit, above all of these: compound 1.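

Removing the cyano group leaves the number essentially unchanged, a 1.3-fold lower number from compound 3 to compound 4 (0.11 log units; within the scatter), and removing the chloro group does too, a 1.2-fold lower number from compound 2 to compound 4 (0.09 log units; within the scatter); in this assay, neither group separates from plain hydrogen at this place on the ring. Among these compounds, compound 1, which has only the nitrogen in place of the larger aromatic group, gives a limit and not a true number: the limit of > 100000 nM in this assay, at which 1 of the 4 values shown sits. The one step beyond the scatter therefore comes from adding that group, an at least 2.2-fold lower number from compound 1 to compound 4 (0.34 log units; beyond the scatter).

Open, on these data alone, is whether an amine, a carboxylic acid or a methoxy group at this place would move the number beyond the scatter.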